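Swapping fluoro for bromo on the shared core

A few compounds are considered here, and "the series" means these few. Any claim that something is new, unique, unknown or untested is made for them only; others in the source may bear on it.

compound 1 `CCCNNC(=O)c1ccc(CNC(=O)c2cc3cc(O)ccc3o2)cc1` gives 40 nM
compound 2 `C=CCOc1ccc2oc(C(=O)NCc3ccc(C(=O)NNCCC)cc3)cc2c1` gives 53.8 nM
compound 3 `CCCNNC(=O)c1ccc(CNC(=O)c2cc3cc(F)ccc3o2)cc1` gives 56.5 nM

In a functional assay on MV4-11 cells (Homo sapiens) for antiproliferative activity, with a stated time of 48 h (a lower number here means a stronger inhibitor, a higher number a weaker inhibitor), these three compounds do not separate from one another. Compound 3 stands level with the other two, since a 1.4-fold higher number from compound 1 to compound 3 (0.15 log units; within the scatter) and a 1.1-fold higher number from compound 2 to compound 3 (0.02 log units; within the scatter) both lie within the scatter.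

Compound 4 `CCCNNC(=O)c1ccc(CNC(=O)c2cc3cc(Br)ccc3o2)cc1` has not yet been measured. It differs from compound 3 by bromo in place of fluoro on an aromatic carbon and is otherwise unchanged.

The measured steps that bear on this change all concern the group on that same carbon, which has been hydroxy, allyloxy and fluoro. Alongside the two steps above, a 1.3-fold higher number from compound 1 to compound 2 (0.13 log units; within the scatter) is also within the scatter. Going by the values given here, no bromo compound has been measured, so this rests on those three small steps alone.

No step beyond the scatter is therefore expected in this assay, and the estimated change is a 1.1-fold lower number from compound 3 to compound 4 (0.05 log units; within the scatter) as a result. Compound 4 is expected to give 50 nM, with an estimated range of 25 nM to 100 nM in this measurement.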

Compound 4, half-maximal inhibitory concentration: 159 nM
Beside the measured number, compound 4's estimate is 3.2-fold (0.50 log units) below it; measured number above the stated range.
By their numbers in this assay, from the lowest: compounds 1, 2 and 3 (each within the scatter of the next); then compound 4.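

In this assay, going by these compounds alone, bromo is the first group on this carbon to take the number beyond the scatter: the change shows as a 2.8-fold higher number from compound 3 to compound 4 (0.45 log units; beyond the scatter) and is matched by a 3.0-fold higher number from compound 2 to compound 4 (0.47 log units; beyond the scatter) and a 4.0-fold higher number from compound 1 to compound 4 (0.60 log units; beyond the scatter) as modest steps of the same direction. The position therefore does not accept every group alike, even though hydroxy, allyloxy and fluoro stand level there, and the computed counts for fluoro and bromo are identical, so those counts do not separate compound 3 from compound 4. Nothing available here accounts for this shift in antiproliferative activity.

The compounds shown leave open whether the shift belongs to bromo alone or would also appear with chloro or iodo on the same carbon. They also leave open whether an amine or a methoxy group there would stay level with hydroxy.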